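The compounds below may be only part of what the source reports. "The series", "measured", "known", "first", "only" and "open" are said of these compounds alone.

Measured compounds:
Compound 1, `Nc1ncnc2c1ncn2[C@@H]1O[C@@]2(CO)CO[C@@H]1[C@@H]2O`: > 100000 nM
Compound 2, `CNC(=O)[C@@]12CO[C@@H]([C@H](n3cnc4c(N)ncnc43)O1)[C@@H]2O`: > 100000 nM
Compound 3, `OC[C@@]12CN[C@@H]([C@H](n3cnc4c(NCc5cccc(I)c5)ncnc43)O1)[C@@H]2O`: > 100000 nM

In a functional assay for agonist activity at adenosine receptor A3 (Homo sapiens), with a stated time of 30 min (on this read-out higher numbers stand for an effect only at larger amounts of compound and lower numbers for an effect already at smaller amounts), compound 1 gives only a limit, > 100000 nM. Compound 2 likewise gives only a limit in this assay, > 100000 nM. Compound 3 also reaches only a limit, > 100000 nM. The change from compound 1 to compound 2 is methylcarbamoyl in place of hydroxymethyl on a saturated ring carbon, and the step it made, a step that the two limits leave unreadable from compound 1 to compound 2, cannot be sized, since (the limit of > 100000 nM in this assay, at which 3 of the 3 values shown sit).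

Compound 4, `CNC(=O)[C@@]12CN[C@@H]([C@H](n3cnc4c(NCc5cccc(I)c5)ncnc43)O1)[C@@H]2O`, has not yet been measured. It differs from compound 3 by methylcarbamoyl in place of hydroxymethyl on a saturated ring carbon. Going by the values given here, this is the same kind of change as the one from compound 1 to compound 2, but not the same: in compound 1 the group sits on a five-membered non-aromatic ring with one oxygen, next to the ring oxygen, whereas in compound 3 it sits on a five-membered non-aromatic ring with one nitrogen, two ring bonds from the ring nitrogen. The difference between the core of compound 3 and the core of compound 1 is not broken down here.

Given that the earlier step that the two limits leave unreadable from compound 1 to compound 2 stays unreadable, the step from compound 3 to compound 4 is estimated only loosely as an at least 3.3-fold lower number from compound 3 to compound 4 (0.52 log units; beyond the scatter). Compound 4 is expected to give about 30000 nM in this assay, somewhere between 3000 nM and 100000 nM.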

Compound 4, half-maximal effective concentration: > 100000 nM
Compound 4 was reported as a limit; the forecaster's own chance of this, stated with the estimate: 50%; middle value at least 3.3-fold (0.52 log units) away from the limit.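

In this assay compound 4 gives only a limit, > 100000 nM. No step from compound 3 to compound 4 can be read: the limit of > 100000 nM in this assay, at which 4 of the 4 values shown sit.

The compounds shown leave open whether methylcarbamoyl in place of hydroxymethyl on a saturated ring carbon changes the half-maximal effective concentration at all, and how far any of the four compounds lies from that limit.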